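The compounds below may be only part of what the source reports. "The series", "measured", "known", "first", "only" and "open" are said of these compounds alone.

Measured compounds:
- Compound 1, `CCCCCCCC/C=C\CCCCCCCC(=O)OC[C@@H](COCc1ccccc1)OP(=O)(O)OC[C@H](N)C(=O)O`: 9.6%
- Compound 2, `CCCCCCCCCCCOc1ccccc1CCC(=O)O[C@H]1COCC[C@H]1OP(=O)(O)OC[C@H](N)C(=O)O`: 3.7%

Both compounds were tested in an assay on HEK293 cells for agonist activity at probable G-protein coupled receptor 34 (Mus musculus), with a stated time of 1 h; on this read-out higher numbers stand for larger maximal responses and lower numbers for smaller maximal responses. On this read-out compound 1 gives 9.6% and compound 2 gives 3.7%. The two numbers lie within the usual scatter of each other, so neither compound can be set apart from the other; both reach only a small maximal response.

Compound 3, `CCCCCCCCCCCOc1ccccc1CCC(=O)O[C@@H]1COCC[C@H]1OP(=O)(O)OC[C@H](N)C(=O)O`, has not yet been measured. It is built from compound 2 by one change: the two compounds have the same atoms and bonds; at least one stereo element is drawn with a configuration in one of them and without one in the other: 1 of 4 stereo elements differ; a stereocentre at a saturated ring carbon is drawn S in compound 2 and R in compound 3. Every atom and every bond stays the same; only the drawn configuration at that one ring carbon is turned around.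

Among the measured compounds shown here, no step between two measured compounds shows how such a change in drawn configuration plays out in this assay, so its size and direction cannot be read from the numbers at hand. From the compounds shown here alone, since compound 2 sits near the floor of the read-out, a drop beyond the scatter has little room, while a rise remains open. Compound 3 is therefore expected to give about 6% in this assay, between 0% and 25%, a step of a number 2.3 percentage points higher from compound 2 to compound 3 (within the scatter) that is estimated to stay within the scatter.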

Compound 3, largest response reached (Emax), in percent of the reference or control that the assay uses: 10%
Compound 3: the middle estimate sits 4 percentage points below what was measured, and the stated range covers the measured number.
By their numbers in this assay, from the lowest: compounds 2, 1 and 3 (each within the scatter of the next).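

Turning around the drawn configuration at this one saturated ring carbon, with every atom and bond kept, gives in this assay a number 6.3 percentage points higher from compound 2 to compound 3 (within the scatter) and so leaves the two forms not set apart. This pair is the only one shown that isolates a single change, and at this stereocentre neither drawn configuration gives more than a small maximal response. One point limits how firmly this pair can be read: the fact that one of compounds 2 and 3 is drawn with a defined configuration and the other without, at the place where they differ.

Among the compounds shown here, whether turning around any of the other stereo elements would give a response clear of the scatter remains open, since only this ring carbon has been varied in a matched pair. Also open, from the compounds shown here alone, is whether an amide in place of the ester that joins the side chain to the ring would give a larger maximal response in this assay in either configuration.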